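The source may report more compounds than this note shows. Statements on the series, on what has been measured and on what is new or still open speak of the compounds shown alone.

Among the measured compounds shown here, in an ADME assay on Vero cells (Chlorocebus sabaeus) for cytotoxicity, read by CellTiter-Glo, with a stated time of 72 h (a lower number here means that less compound is tolerated, a higher number that more compound is tolerated), compound 1 (`CCNc1n[n+]([O-])c2ccccc2[n+]1[O-]`) gives 17 ug/mL, the higher of the two numbers measured so far. Compound 2 (`CC(C)(C)Nc1n[n+]([O-])c2ccccc2[n+]1[O-]`) gives 8 ug/mL. For the measured compounds named here, the one measured step is a 2.1-fold lower number from compound 1 to compound 2 (0.33 log units; beyond the scatter), with tert-butyl in place of ethyl on a nitrogen on an aromatic ring.

Compound 3 (`CCNc1n[n+]([O-])c2cccc(C)c2[n+]1[O-]`) keeps the ethyl group of compound 1 and differs on the core instead: methyl in place of hydrogen on an aromatic carbon. This is methyl in place of hydrogen on an aromatic carbon, ortho to a fused ring and meta to a fused ring. Going by the values given here, the measured step lies on a nitrogen and not on an aromatic carbon, so it bears only loosely on this change, and no measured step shows what a methyl group does at this place. Resting on compound 2 and its 8 ug/mL, a small downward move at most is expected in this assay, quite possibly none beyond the scatter. The estimate is a 1.3-fold lower number from compound 1 to compound 3 (0.12 log units; within the scatter). The expected value for compound 3 is 13 ug/mL, with an estimated range from 6 ug/mL to 28 ug/mL.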

Compound 3, half-maximal cytotoxic concentration: 22 ug/mL
Beside the measured number, compound 3's estimate is 1.7-fold (0.23 log units) below it; the measured number falls inside the stated range.
By their numbers in this assay, from the lowest: compound 2; then compounds 1 and 3 (each within the scatter of the next).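

In this assay the new result is (a 1.3-fold higher number from compound 1 to compound 3 (0.11 log units; within the scatter)), so methyl in place of hydrogen on an aromatic carbon, ortho to a fused ring and meta to a fused ring, leaves the number within the scatter of compound 1. Among the compounds shown here, this is the first reading from an aromatic carbon of the shared core, as the earlier step (a 2.1-fold lower number from compound 1 to compound 2 (0.33 log units; beyond the scatter)) concerned only the group on the nitrogen. At this position, a methyl group is therefore tolerated without a move that can be told apart from repeat measurement, whereas tert-butyl in place of ethyl on the nitrogen gave a step beyond the scatter. Nothing measured here bears on the reason for this result.

Open, going by these compounds, is whether a group larger than methyl or of another kind, such as a methoxy group, an amine or a carboxylic acid, would be equally tolerated at this place, and whether a methyl group on another aromatic carbon of the core would read the same. Also open, on these data alone, is whether the methyl group and the tert-butyl group would act independently when carried together on the core of compound 1.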